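Adding One Chain Carbon to a Dipentylamino Compound

The source may report more compounds than this note shows. Statements on the series, on what has been measured and on what is new or still open speak of the compounds shown alone.

In a functional assay on LNCaP cells (Homo sapiens) for antiproliferative activity, read by WST assay, with a stated time of 3 days (on this read-out lower numbers stand for stronger inhibition and higher numbers for weaker inhibition), compound 1 (`CCN(CC)CCCCCOc1c(-c2cc(OC)c(OC)c(OC)c2)oc2ccccc2c1=O`) gives 10000 nM while compound 2 (`CCCCN(CCCC)CCCCCOc1c(-c2cc(OC)c(OC)c(OC)c2)oc2ccccc2c1=O`) gives 7800 nM and compound 3 (`CCCCCN(CCCCC)CCCOc1c(-c2cc(OC)c(OC)c(OC)c2)oc2ccccc2c1=O`) gives 5100 nM on the same read-out. Compound 3 stands level with the other two, since none of these three numbers can be told apart from another beyond the scatter of repeated measurements.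

Compound 4 (`CCCCCN(CCCCC)CCCCOc1c(-c2cc(OC)c(OC)c(OC)c2)oc2ccccc2c1=O`) carries (dipentylamino)methyl in place of dipentylamino on a saturated chain carbon, three bonds along the chain from an oxygen on an aromatic ring. For the measured compounds named here, no measured pair makes this exact change alone. The nearest guides are compound 1 and compound 2, whose steps to compound 3 change the amino end and the chain length together. The step of a 2.0-fold lower number from compound 1 to compound 3 (0.29 log units; within the scatter) and the step of a 1.5-fold lower number from compound 2 to compound 3 (0.18 log units; within the scatter) are both small, and the step of a 1.3-fold lower number from compound 1 to compound 2 (0.11 log units; within the scatter) is small as well.

With those small steps as the guide, the step of a 1.1-fold higher number from compound 3 to compound 4 (0.03 log units; within the scatter) is expected to stay within the scatter in this assay with no clear direction. The estimate for compound 4 is 5500 nM (expected range 2800 nM to 10000 nM).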

Compound 4, half-maximal inhibitory concentration: 9700 nM
Compound 4: the middle estimate sits 1.8-fold (0.25 log units) below what was measured; measured number inside the range.
By their numbers in this assay, from the lowest: compounds 3, 2, 4 and 1 (each within the scatter of the next).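

Compound 4 and compound 3 differ by one carbon in the chain, with (dipentylamino)methyl in place of dipentylamino, and this is the first step shown that leaves the amino end untouched: in this assay it reads as a 1.9-fold higher number from compound 3 to compound 4 (0.28 log units; within the scatter) and so lies within the scatter. Changing the amino end and the chain length together gives a 1.2-fold higher number from compound 2 to compound 4 (0.09 log units; within the scatter) and a 1.0-fold lower number from compound 1 to compound 4 (0.01 log units; within the scatter), and both of these also lie within the scatter, so neither kind of change separates compound 4 from the other three compounds. At this position, then, the four compounds show no measurable effect of either the length of the chain or the size of the alkyl groups on the nitrogen, and no supporting measurement is available to explain this.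

The compounds shown leave open whether a ring amine such as piperidine or morpholine at the end of the chain, or a longer chain carrying the dipentylamino group, would give a step beyond the scatter. They also leave open whether a carboxylic acid at the end of the chain would do so.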